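One Ring Swap, Seen Twice, in Weak Inhibitors

The source may hold more compounds than are shown below. What is called first, only, known or untested is meant among the compounds shown, and "the series" means these compounds.

Three compounds have been measured in an assay on isolated protein for inhibition of matrix metalloproteinase-9 (Homo sapiens); a lower number here means a stronger inhibitor, a higher number a weaker inhibitor:

Compound 1 `O=C(OCCCCOc1ccccc1)c1cccc(=O)[nH]1` gives 94000 nM.
Compound 2 `O=C(OCc1cccc(C(F)(F)F)c1)c1cccc(S)n1` gives 126000 nM.
Compound 3 `O=C(OCCCCOc1ccccc1)c1cccc(S)n1` gives 83000 nM.

Within the data shown here, all three numbers are high, so each is a weak inhibitor, and no pair of them is separated by more than the usual scatter. Compound 3 and compound 1 share a core and differ in one place: a group of 7 heavy atoms (5 carbon, 1 nitrogen, 1 oxygen; one six-membered aromatic ring with 1 hetero atom) in place of a group of 7 heavy atoms (5 carbon, 1 nitrogen, 1 sulfur; one six-membered aromatic ring with 1 hetero atom), on a carbonyl carbon. That change gave a 1.1-fold higher number from compound 3 to compound 1 (0.05 log units; within the scatter), a step that lies within the scatter. The difference between the cores of compound 2 and compound 3 is not broken down here.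

Compound 4 `O=C(OCc1cccc(C(F)(F)F)c1)c1cccc(=O)[nH]1` is not yet measured. It stands to compound 2 as compound 1 stands to compound 3: a group of 7 heavy atoms (5 carbon, 1 nitrogen, 1 oxygen; one six-membered aromatic ring with 1 hetero atom) in place of a group of 7 heavy atoms (5 carbon, 1 nitrogen, 1 sulfur; one six-membered aromatic ring with 1 hetero atom), on a carbonyl carbon. The place is the same in both cases, so this is the same change. Because the earlier instance gave a 1.1-fold higher number from compound 3 to compound 1 (0.05 log units; within the scatter), the step from compound 2 is expected to be small as well, about a 1.1-fold higher number from compound 2 to compound 4 (0.05 log units; within the scatter). Compound 4 is therefore estimated at 140000 nM, expected to fall between 70000 nM and 280000 nM.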

Compound 4, half-maximal inhibitory concentration: > 150 nM
Compound 4 ended at the assay's limit; the forecaster's own chance of this, stated with the estimate: 25%; the middle value is on the limit's open side.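

Compound 4 gives > 150 nM in this assay, which is a limit of the assay and not a number. The step from compound 2 to compound 4 therefore cannot be read. The compounds shown leave open whether this ring swap, which stayed within the scatter from compound 3 to compound 1, behaves the same way on the core of compound 2.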